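This account rests on a few compounds, and the source may have more. Where it says the series, first, only, none or still open, it means among the compounds named here.

Measured in an ADME assay on microsomes from liver (Rattus norvegicus) for metabolic stability, read by LC-MS, using NADPH, with stated times of 6 min and 10 min, tested at 0.5 uM (on this read-out lower numbers stand for a less stable compound and higher numbers for a more stable compound), for these compounds:

Compound 1 `CC(=O)N1CCN(c2cccc(-c3cc(Cl)c4c(N)ncnn34)c2C)C(=O)C1(C)C` gives 19%
Compound 2 `CC(=O)N1CCN(c2cc(C)cc(-c3cc(Cl)c4c(N)ncnn34)c2)C(=O)C1(C)C` gives 100%
Compound 3 `CC(=O)N1CCN(c2cc(-c3cc(Cl)c4c(N)ncnn34)ccc2C(F)(F)F)C(=O)C1(C)C` gives 87%

Compound 3 at 87% stands second of the three. It is lower than compound 2 and higher than compound 1, and both gaps lie beyond the usual scatter. Compound 4 `COc1ccc(-c2cc(Cl)c3c(N)ncnn23)cc1N1CCN(C(C)=O)C(C)(C)C1=O` has methoxy in place of trifluoromethyl on an aromatic carbon, ortho to a large group and para to a large group (methoxy in place of trifluoromethyl on an aromatic carbon). Among the measured compounds shown here, no measured pair differs in one place only, so no direct guide exists. Compound 1 at 19% shows that low values do occur among these compounds. A fall beyond the scatter is therefore expected, with the estimated step of a number 22 percentage points lower from compound 3 to compound 4 (beyond the scatter) in this assay taken as moderate. Compound 4 is expected to give 65% within an estimated range from 35% to 92% in this measurement.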

Compound 4, percent of the compound remaining: 91%
Estimate against measurement, compound 4: 26 percentage points below; measured number inside the range.
By their numbers in this assay, from the lowest: compound 1; then compounds 3, 4 and 2 (each within the scatter of the next, the first and the last beyond it).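

In this assay, among the compounds shown here, compounds 3 and 4 form the first pair that differs in one place only, and the step is a number 4 percentage points higher from compound 3 to compound 4 (within the scatter). At this aromatic carbon, ortho to a large group and para to a large group, methoxy and trifluoromethyl therefore cannot be told apart on this read-out, although they differ in heavy atoms and hydrogen-bond acceptors. No measured evidence explains this result. The compounds shown leave open how an amine or a carboxylic acid would read on this same carbon, and whether a longer chain such as ethoxy would stay within the scatter of compound 3.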